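The source may hold more compounds than are shown below. What is called first, only, known or untested is meant among the compounds shown, and "the series" means these compounds.

The two measured compounds share one core and differ only in the acid-bearing group on the oxygen. Compound 1 `O=C(O)COc1ccc(NCc2cccc(Oc3ccccc3)c2)cc1` carries a carboxymethyl group there, and in a functional assay on CHO cells for agonist activity at Free fatty acid receptor 1 (Homo sapiens) (on this read-out higher numbers stand for an effect only at larger amounts of compound and lower numbers for an effect already at smaller amounts), compound 1 gives 2040 nM. Compound 2 `CC(C)(Oc1ccc(NCc2cccc(Oc3ccccc3)c2)cc1)C(=O)O` carries a 1-carboxy-1-methylethyl group in its place. For compound 2 this assay reports only a limit, < 10000 nM, so compound 2 stands at the limit of < 10000 nM in this assay, at which 1 of the 2 values shown sits, and not at a number. The step that the limit leaves unreadable from compound 1 to compound 2 therefore cannot be read in size. Compound 3 `O=C(O)CSc1ccc(NCc2cccc(Oc3ccccc3)c2)cc1` is not yet measured. Its change from compound 2 is (carboxymethyl)sulfanyl in place of 1-carboxy-1-methylethoxy on an aromatic carbon. Going by the values given here, of the measured steps only the one from compound 1 to compound 2 touches this part of the molecule, and its size is not readable, so no measured step sets a size for the change in this assay. Among the compounds with values here, compound 1 is the one compound here with a number, and its value 2040 nM is the only anchor. Compound 3 is therefore expected near that anchor, at about 2500 nM, within a range from 800 nM to 8000 nM. The expected step is a step that the limit leaves unreadable from compound 2 to compound 3, which can only be set against a limit.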

Compound 3, half-maximal effective concentration: 324 nM
Estimate against measurement, compound 3: 7.7-fold (0.89 log units) above; measured number outside the range, below it.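

In this assay, (carboxymethyl)sulfanyl in place of carboxymethoxy on an aromatic carbon gives a 6.3-fold lower number from compound 1 to compound 3 (0.80 log units; beyond the scatter). Going by these compounds alone, this is the first step of readable size at this position, and it shows that the read-out responds when the oxygen that carries the carboxymethyl group is exchanged for sulfur, with the rest of the molecule unchanged. The steps that touch compound 2 cannot be read in size, since compound 2 has only a limit and not a number: the limit of < 10000 nM in this assay, at which 1 of the 3 values shown sits.

The compounds shown leave open how the 1-carboxy-1-methylethyl group would read on sulfur, and whether a longer chain carrying the carboxylic acid on the sulfur would keep the lower number of compound 3 in this assay. They also do not show how a sulfone or a methylene group in place of the sulfur would compare with compound 3.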